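The compounds below may be only part of what the source reports. "The series", "measured", "known", "first", "only" and "open" are said of these compounds alone.

Compound 1 `CCNc1ncc(C#Cc2cccc(C)c2)cn1`: "not active" (no number reported)
Compound 2 `CNc1ncc(C#Cc2cccc(C)c2)cn1`: 21100 nM

For the measured compounds named here, in an assay on HEK293 cells for positive allosteric modulation of metabotropic glutamate receptor 5 (Rattus norvegicus) (on this read-out lower numbers stand for an effect already at smaller amounts and higher numbers for an effect only at larger amounts of compound), compound 2 gives 21100 nM, the only number in the set; compound 1 gives "not active" (no number reported) without a number. Compound 3 `COc1ncc(C#Cc2cccc(C)c2)cn1` differs from compound 2 by methoxy in place of methylamino on an aromatic carbon. Going by the values given here, no step between two measured compounds is available to guide the size of this change, so only a loose expectation can be given. For compound 3 the step of a 1.4-fold higher number from compound 2 to compound 3 (0.15 log units; within the scatter) is expected to stay within the usual scatter or to go toward a weaker effect. Compound 3 is therefore estimated at 30000 nM, within a range from 10000 nM to 100000 nM.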

Compound 3, half-maximal effective concentration: "not active" (no number reported)
The entry for compound 3 holds no number, so the estimate cannot be set against anything.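

For the compounds shown here, compound 3 has no number, so no step from compound 2 to compound 3 can be read, and no measured evidence bears on this result. On these data alone, how methoxy and methylamino compare in this assay stays open.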